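Propoxy for propyl on the thiophene sulfonylurea

A few compounds are considered here, and "the series" means these few. Any claim that something is new, unique, unknown or untested is made for them only; others in the source may bear on it.

This account follows one step among three measured compounds sharing a core. Compound 1 `CCc1ccc(S(=O)(=O)NC(=O)Nc2ccc(Cl)cc2)s1` gives 89% in a functional assay on the whole organism (6C3HED cells, Mus musculus) for inhibition, at a dose of 300 mg/kg by the oral route; on this read-out higher numbers stand for more inhibition at the one dose given (going by the name of the read-out) and lower numbers for less inhibition. Compound 2 `CCOc1ccc(S(=O)(=O)NC(=O)Nc2ccc(Cl)cc2)s1` gives 96% in this assay, and the step of a number 7 percentage points higher from compound 1 to compound 2 (within the scatter) lies within the scatter. Compound 3 `CCCc1ccc(S(=O)(=O)NC(=O)Nc2ccc(Cl)cc2)s1` gives 39% in this assay, the lowest of the three numbers; the step of a number 50 percentage points lower from compound 1 to compound 3 (beyond the scatter) and the step of a number 57 percentage points lower from compound 2 to compound 3 (beyond the scatter) are both large.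

Compound 4 `CCCOc1ccc(S(=O)(=O)NC(=O)Nc2ccc(Cl)cc2)s1` differs from compound 3 by one change: propoxy in place of propyl on an aromatic carbon. The step that bears most directly on it is a number 7 percentage points higher from compound 1 to compound 2 (within the scatter), where the same kind of exchange, an alkoxy for an alkyl group of the same carbon count, moved the number only within the scatter. The step of a number 57 percentage points lower from compound 2 to compound 3 (beyond the scatter) shows that the compound bearing propyl sits far below the compound bearing ethoxy, but whether that gap comes from the oxygen or from the chain length cannot be separated with these three compounds.

Compound 4 is therefore expected to give about 48%, within 20% to 85%. The expected step is a number 9 percentage points higher from compound 3 to compound 4 (within the scatter), which is not a confident call in either direction.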

Compound 4, a percentage reported as inhibition, in the whole organism at one dose (the size of the read-out at that dose, not a potency): 63%
Compound 4: the middle estimate sits 15 percentage points below what was measured; measured number inside the range.
By their numbers in this assay, from the lowest: compound 3; then compound 4; then compounds 1 and 2 (each within the scatter of the next).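

In this assay, the exchange of an alkyl group for an alkoxy group of the same carbon count now matters: propoxy in place of propyl gives a number 24 percentage points higher from compound 3 to compound 4 (beyond the scatter), whereas ethoxy in place of ethyl stayed within the scatter. Lengthening the chain still lowers the number when the oxygen is present, with a number 33 percentage points lower from compound 2 to compound 4 (beyond the scatter), and propoxy in place of ethyl gives a number 26 percentage points lower from compound 1 to compound 4 (beyond the scatter). The added methyl therefore lowers the number on both cores, but not by the same amount: the same change on two cores in this assay, a number 50 percentage points lower (beyond the scatter) from compound 1 to compound 3 and a number 33 percentage points lower (beyond the scatter) from compound 2 to compound 4, 17 percentage points apart, beyond the scatter of two such steps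

The compounds shown leave open whether the gap between alkoxy and alkyl groups would grow further with butoxy against butyl. They also leave open where an amine on this aromatic carbon would stand, and how any of these numbers would shift at another dose.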